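The source may hold more compounds than are shown below. What is called first, only, known or untested is meant among the compounds shown, and "the series" means these compounds.

Measured compounds:
compound 1 `CCCCNC(=O)C1CCN(c2nc(N)c3cc(OC)c(OC)cc3n2)CC1` — 0.67 nM
compound 2 `COc1cc2nc(N3CCC(C(=O)NC4CCCC4)CC3)nc(N)c2cc1OC` — 0.63 nM
compound 3 `COc1cc2nc(N3CCC(C(=O)NCCO)CC3)nc(N)c2cc1OC` — 1.73 nM

In an assay on isolated protein for displacement of a labelled ligand from Adrenergic receptor alpha-1 (Rattus norvegicus) (a higher number here means a weaker inhibitor, a lower number a stronger inhibitor), compound 1 holds the second highest of the three numbers. Compound 2 stands nearest to it, a 1.1-fold lower number from compound 1 to compound 2 (0.03 log units; within the scatter), and compound 3 furthest, a 2.6-fold higher number from compound 1 to compound 3 (0.41 log units; beyond the scatter). Compound 4 `CCN(CC)C(=O)C1CCN(c2nc(N)c3cc(OC)c(OC)cc3n2)CC1` has not yet been measured; it differs from compound 1 by diethylamino in place of butylamino on a carbonyl carbon. Going by the values given here, no measured step makes this kind of change: the two known steps only swap the group on the amide-type nitrogen, and the values of compound 1, compound 2 and compound 3 show that such swaps move the number little. For compound 4 a small step is therefore expected, a 1.9-fold higher number from compound 1 to compound 4 (0.29 log units; within the scatter). The estimated value for compound 4 is 1.3 nM, between 0.4 nM and 4 nM.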

Compound 4, inhibition constant: 1.11 nM
Beside the measured number, compound 4's estimate is 1.2-fold (0.07 log units) above it; low and high end bracket the measured number.
By their numbers in this assay, from the lowest: compounds 2, 1, 4 and 3 (each within the scatter of the next, the first and the last beyond it).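

Swapping butylamino for diethylamino on the carbonyl carbon removes the amide hydrogen, yet in this assay the step stays within the scatter (a 1.7-fold higher number from compound 1 to compound 4 (0.22 log units; within the scatter)). Compound 4 also lies within the scatter of the other two amides (a 1.8-fold higher number from compound 2 to compound 4 (0.25 log units; within the scatter); a 1.6-fold lower number from compound 3 to compound 4 (0.19 log units; within the scatter)), although compound 2 and compound 3 lie beyond it from each other. So, in these compounds, the amide hydrogen is not needed for a number in this range.

As far as these compounds go, how a carboxylic acid or a morpholine amide would behave on this carbonyl carbon stays open. Nothing here gives a reason for the result.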